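This account rests on a few compounds, and the source may have more. Where it says the series, first, only, none or still open, it means among the compounds named here.

Compound 1 `N#CC1=C(N)N(c2ccc(S(N)(=O)=O)cc2)C2=C(CCCC2)C1c1ccccc1`: 30%
Compound 2 `N#CC1=C(N)N(c2ccc(S(N)(=O)=O)cc2)C2=C(CCCC2)C1c1ccccc1O`: 100%
Compound 3 `COc1ccccc1C1C(C#N)=C(N)N(c2ccc(S(N)(=O)=O)cc2)C2=C1CCCC2`: 100%

In a functional assay on Ehrlich cells (Mus musculus) for cytotoxicity, read by trypan blue exclusion, with a stated time of 2 h, tested at 100 ug/mL (on this read-out lower numbers stand for a weaker effect and higher numbers for a stronger effect at the one concentration tested), compound 3 stands level with compound 2 at the digits shown, the two together the highest of the three numbers, while compound 1 sits far lower, as a number 70 percentage points higher from compound 1 to compound 3 (beyond the scatter) shows. Compound 4 `N#CC1=C(N)N(c2ccc(S(N)(=O)=O)cc2)C2=C(CCCC2)C1c1ccccc1Cl` differs from compound 3 in one place: chloro in place of methoxy on an aromatic carbon. Within the data shown here, two measured steps bear on this change. Putting a group onto that aromatic carbon gave a number 70 percentage points higher from compound 1 to compound 2 (beyond the scatter) and a number 70 percentage points higher from compound 1 to compound 3 (beyond the scatter), and exchanging one oxygen group for another gave no change at the digits printed from compound 2 to compound 3 (within the scatter). Among the measured compounds shown here, no measured step carries chloro, so the expected step is a number 15 percentage points lower from compound 3 to compound 4 (beyond the scatter), small and downward if any. Compound 4 is therefore estimated at 85%, within 50% to 100%.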

Compound 4, a percentage reported as activity, at one concentration (the size of the read-out at that concentration, not a potency): 10%
The estimate for compound 4 lay 75 percentage points above the measured number, and the stated range ends above it.
By their numbers in this assay, from the lowest: compound 4; then compound 1; then compounds 2 and 3 (each within the scatter of the next).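

In this assay, a group on this aromatic carbon does not always raise the number: chloro in place of hydrogen gives a number 20 percentage points lower from compound 1 to compound 4 (beyond the scatter), the opposite direction to hydroxy and methoxy. Set against those two oxygen groups, chloro gives a number 90 percentage points lower from compound 3 to compound 4 (beyond the scatter) and a number 90 percentage points lower from compound 2 to compound 4 (beyond the scatter), so the identity of the group matters, not merely the presence of one. Nothing available explains what separates chloro from the two oxygen groups. The compounds shown leave open whether other groups at this carbon follow hydroxy and methoxy or follow chloro; an ethoxy group, an amine or bromo would each test this.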